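The source may hold more compounds than are shown below. What is called first, only, known or untested is meant among the compounds shown, and "the series" means these compounds.

Measured so far in a functional assay on the whole organism with Rattus norvegicus as the target; a lower number here means that less compound is needed, a higher number that more compound is needed for the effect:
- compound 1 `COC(=O)CC/C=C\CC[C@H]1C(=O)C[C@@H](O)[C@@H]1/C=C/C[C@@](C)(O)C#CC1=CCCC1` — compound 1 gives > 3.16 mg/kg, a limit of the assay only
- compound 2 `COC(=O)CC/C=C\CC[C@H]1C(=O)C[C@@H](O)[C@@H]1/C=C/CC(C)(O)CCC1=CCCC1` — compound 2 gives 1.18 mg/kg
- compound 3 `COC(=O)CC/C=C\CC[C@H]1C(=O)C[C@@H](O)[C@@H]1/C=C/CC(C)(O)CCC1CCCC1` — compound 3 gives 1.31 mg/kg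

For the measured compounds named here, compound 1 is the one compound of the three that stands only at a limit, the line (the limit of > 3.16 mg/kg in this assay, at which 1 of the 3 values shown sits), so its place among the numbers is known only as being on the higher side of the set. The two steps away from it are both beyond the scatter: an at least 2.6-fold lower number from compound 1 to compound 2 (0.42 log units; beyond the scatter) and an at least 2.4-fold lower number from compound 1 to compound 3 (0.38 log units; beyond the scatter). Between compounds 2 and 3 there is no step of note, a 1.1-fold higher number from compound 2 to compound 3 (0.05 log units; within the scatter).

Compound 4 `COC(=O)CC/C=C\CC[C@H]1C(=O)C[C@@H](O)[C@@H]1/C=C/C[C@@](C)(O)/C=C/C1=CCCC1` is not yet measured. It differs from compound 1 by 2-(cyclopent-1-en-1-yl)ethenyl in place of 2-(cyclopent-1-en-1-yl)ethynyl on a saturated chain carbon bound to an oxygen on a saturated carbon and two saturated chain carbons. Removing the triple bond entirely gave the two measured steps above; the 2-(cyclopent-1-en-1-yl)ethenyl group of compound 4 keeps one bond of unsaturation, so a step of the same direction but not necessarily the full size is expected, an at least 1.7-fold lower number from compound 1 to compound 4 (0.24 log units; that floor lies within the scatter). Compound 4 is therefore estimated at 1.8 mg/kg, with a range of 0.8 mg/kg to 4 mg/kg; a limit reading remains possible since compound 1 itself is only a limit.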

Compound 4, dose for half-maximal effect: > 3.16 mg/kg
Compound 4 gave a limit, no number (the forecaster's own chance of this, stated with the estimate: 30%); at least 1.7-fold (0.24 log units) between middle value and limit.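

In this assay compound 4 joins compound 1 at a limit of the assay, not a number: the limit of > 3.16 mg/kg in this assay, at which 2 of the 4 values shown sit.

The triple bond is therefore not the only chain feature that goes with a limit reading, since the double-bonded chain of compound 4 separates from the saturated chains: an at least 2.6-fold higher number from compound 2 to compound 4 (0.42 log units; beyond the scatter), and an at least 2.4-fold higher number from compound 3 to compound 4 (0.38 log units; beyond the scatter). The step between compound 1 and compound 4 cannot be read, so the ethenyl and ethynyl linkers cannot be ranked against each other.

Going by these compounds, how far the true values of compound 1 and compound 4 lie past the limit remains open. Also open, on these data alone, is whether the low numbers of compound 2 and compound 3 would hold with a phenyl group in place of the five-membered ring.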